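Swapping the Methylpyrazole for an Aminophenyl Arm

The source may hold more compounds than are shown below. What is called first, only, known or untested is meant among the compounds shown, and "the series" means these compounds.

The measured compounds so far:
- compound 1 `COC(=O)c1sc2cc(-c3ccc(-c4cccs4)s3)cnc2c1N`, compound 2 `COC(=O)c1sc2cc(-c3cnn(C)c3)cnc2c1N`, compound 3 `COC(=O)c1sc2cc(-c3cc(OC)cc(OC)c3)cnc2c1N`.

In a functional assay on A-375 cells (Homo sapiens) for inhibition, read by sulforhodamine B assay, with a stated time of 48 h (on this read-out lower numbers stand for stronger inhibition of growth and higher numbers for weaker inhibition of growth), compound 3 gives 82000 nM. Compound 1 reaches only a limit of the assay, > 75000 nM, so no number is known for it. Among the compounds with values here, compound 2 likewise reaches only a limit, > 150000 nM, and it therefore stands with no number of its own; one further value among the three is also a limit, and the single firm number, from compound 3, is itself weak. Because compound 2 sits at the limit of > 150000 nM in this assay, at which 1 of the 3 values shown sits, the step to any new compound can only be judged from one side.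

The unmeasured compound 4 `COC(=O)c1sc2cc(-c3ccc(N)cc3)cnc2c1N` differs from compound 2 in one place: 4-aminophenyl in place of 1-methyl-1H-pyrazol-4-yl on an aromatic carbon. Within the data shown here, with no measured step of this kind available, the expectation is a change in this assay that may reach past the scatter toward stronger inhibition, but without leaving the weak region. Compound 4 is estimated at 60000 nM, within 15000 nM to 200000 nM, meaning an expected step of an at least 2.5-fold lower number from compound 2 to compound 4 (0.39 log units; beyond the scatter).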

Compound 4, concentration for 50% growth inhibition: 80800 nM
Estimate against measurement, compound 4: 1.3-fold (0.13 log units) below; low and high end bracket the measured number.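

In this assay, compound 4 gives a firm number where compound 2 gave only a limit, so this aromatic carbon can carry 4-aminophenyl and still return a measurable value. The change reads as an at least 1.8-fold lower number from compound 2 to compound 4 (0.26 log units; that floor lies within the scatter), which means a real gain beyond the usual scatter is neither shown nor ruled out. Its true size stays unknown because compound 2 stands at a limit of the assay: the limit of > 150000 nM in this assay, at which 1 of the 4 values shown sits.

Inhibition of growth remains weak with 4-aminophenyl, and what its amine contributes, as against the phenyl ring alone, stays open. Whether a hydroxyl in place of that amine, or an acetamide built on it, would move the number further cannot be told from the compounds shown.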